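The source may report more compounds than this note shows. Statements on the series, on what has been measured and on what is new or still open speak of the compounds shown alone.

Compound 1 `O=[N+]([O-])C1=NNc2ncnn2C1c1ccc(O)c(O)c1`: > 1630000 nM, a limit of the assay and not a number
Compound 2 `O=[N+]([O-])C1=NNc2ncnn2C1c1ccc(O)c(O)c1O`: 228000 nM
Compound 3 `O=[N+]([O-])C1=NNc2ncnn2C1c1ccc(O)cc1O`: 90000 nM

These values come from an ADME assay on MDCK cells (Canis lupus familiaris) for cytotoxicity; on this read-out lower numbers stand for higher toxicity in this test and higher numbers for lower toxicity in this test. Of the two actual numbers, the higher belongs to compound 2 at 228000 nM, and compound 3 lies lower at 90000 nM. The entry for compound 1 is a limit.

Compound 4 `CSc1nc2n(n1)C(c1ccc(O)c(O)c1O)C([N+](=O)[O-])=NN2` is the next compound to follow from compound 2. The change is methylsulfanyl in place of hydrogen on an aromatic carbon of the five-membered aromatic ring with 3 nitrogen, between two ring nitrogen atoms.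

Two measured steps are available: an at least 7.1-fold lower number from compound 1 to compound 2 (0.85 log units; beyond the scatter), and a 2.5-fold lower number from compound 2 to compound 3 (0.40 log units; beyond the scatter). Both exchange hydroxy and hydrogen on an aromatic carbon, and neither touches the carbon that changes in compound 4. Going by the values given here, no measured step therefore shows the effect of this change directly. These steps show only that, within this small set, single changes moved the number beyond the scatter. A modest step to a lower number is therefore expected, though the direction is poorly supported. The expected step is a 1.5-fold lower number from compound 2 to compound 4 (0.18 log units; within the scatter). For compound 4 the estimated value is 150000 nM, with an expected range from 40000 nM to 600000 nM.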

Compound 4, half-maximal cytotoxic concentration: 196000 nM
Beside the measured number, compound 4's estimate is 1.3-fold (0.12 log units) below it; low and high end bracket the measured number.
By their numbers in this assay, from the lowest: compound 3; then compounds 4 and 2 (each within the scatter of the next). At a limit, above all of these: compound 1.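

In this assay, placing methylsulfanyl on the aromatic carbon between two ring nitrogen atoms gives a 1.2-fold lower number from compound 2 to compound 4 (0.07 log units; within the scatter) and so the two numbers cannot be told apart. Going by these compounds alone, this is the first view of this carbon of the five-membered aromatic ring: the earlier steps exchanged hydroxy and hydrogen on an aromatic carbon elsewhere in the molecule, and each of those moved the number beyond the scatter, while this exchange of hydrogen for a group of 2 heavy atoms does not. Nothing available here explains why this change makes so little difference in this test.

From the compounds shown here alone, a single group at this carbon says little about the position as a whole, so it remains open whether an amine, a carboxylic acid or a longer chain there would also stay within the scatter of compound 2. Going by these compounds, it is also open whether methylsulfanyl would behave the same way alongside the different hydroxy arrangements of compound 1 and compound 3.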